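Replacing an Ester with a Methanesulfonamide on Compound 3

The source may report more compounds than this note shows. Statements on the series, on what has been measured and on what is new or still open speak of the compounds shown alone.

Measured compounds:
compound 1, `CCc1ccc(-c2ccc(N(C[C@@H](N)[C@@H](C)CC)C(=O)[C@@H]3C[C@H]3c3ccccc3)cc2)cc1`: 44 nM
compound 2, `CCCc1ccc(-c2ccc(N(C[C@@H](N)[C@@H](C)CC)C(=O)[C@@H]3C[C@H]3c3ccccc3)cc2)cc1`: 61 nM
compound 3, `CCOC(=O)c1ccc(-c2ccc(N(C[C@@H](N)[C@@H](C)CC)C(=O)[C@@H]3C[C@H]3c3ccccc3)cc2)cc1`: 260 nM

In a functional assay for agonist activity at G protein-coupled receptor 88 (Homo sapiens), read by HTRF and cAMP accumulation (a lower number here means that less compound is needed, a higher number that more compound is needed for the effect), compound 3 gives the highest of the three numbers. The steps of a 5.9-fold higher number from compound 1 to compound 3 (0.77 log units; beyond the scatter) and a 4.3-fold higher number from compound 2 to compound 3 (0.63 log units; beyond the scatter) both lie beyond the scatter, while the step of a 1.4-fold higher number from compound 1 to compound 2 (0.14 log units; within the scatter) lies within it, so the two alkyl-bearing compounds cannot be ordered against each other, but compound 3 sits clearly apart from both.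

Compound 4, `CC[C@H](C)[C@H](N)CN(C(=O)[C@@H]1C[C@H]1c1ccccc1)c1ccc(-c2ccc(NS(C)(=O)=O)cc2)cc1`, is derived from compound 3 by one change: methanesulfonamido in place of ethoxycarbonyl on an aromatic carbon. The measured steps that bear on this position are the two that replaced an alkyl group by ethoxycarbonyl, a 5.9-fold higher number from compound 1 to compound 3 (0.77 log units; beyond the scatter) and a 4.3-fold higher number from compound 2 to compound 3 (0.63 log units; beyond the scatter), each a modest rise. For the measured compounds named here, no measured step involves a methanesulfonamido group or any hydrogen-bond donor at this position, so the direction of this particular change is not anchored by the data. Because compound 3 already carries the highest number at 260 nM after a polar substituent entered here, a further polar group is expected to leave the number near that of compound 3 or somewhat above it, without a step beyond the scatter being certain.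

Compound 4 is therefore estimated at 320 nM in this assay, with a range from 80 nM to 1300 nM, which means an expected step of a 1.2-fold higher number from compound 3 to compound 4 (0.09 log units; within the scatter).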

Compound 4, half-maximal effective concentration: 1200 nM
The estimate for compound 4 lay 3.8-fold (0.57 log units) below the measured number, and the stated range covers the measured number.
By their numbers in this assay, from the lowest: compounds 1 and 2 (each within the scatter of the next); then compound 3; then compound 4.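

In this assay the result shows that this position, on an aromatic carbon para to a large group, can move the number well beyond what the ester alone revealed, with a 4.6-fold higher number from compound 3 to compound 4 (0.66 log units; beyond the scatter) on exchanging one substituent for the other. Measured against the alkyl compounds, the shift is larger still, with a 20-fold higher number from compound 2 to compound 4 (1.29 log units; beyond the scatter) and a 27-fold higher number from compound 1 to compound 4 (1.44 log units; beyond the scatter) in a series whose earlier steps at this position were only modest. Ethoxycarbonyl and methanesulfonamido have the same count of heavy atoms and the same count of hydrogen-bond acceptors, and they differ in that methanesulfonamido brings a hydrogen-bond donor, but nothing available ties the rise to that feature or to any other.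

The compounds shown leave open whether the rise follows the amide-type hydrogen on the nitrogen or the sulfonyl group itself, a question that an acetamido group, an N-methyl methanesulfonamido group or a methanesulfonyl group placed directly on the ring would address. They also leave open how a carboxylic acid, an amine or a longer alkyl chain would behave at this same position.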